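Cyclopropyl for Hydroxymethyl on the Triazole Arm

This account rests on a few compounds, and the source may have more. Where it says the series, first, only, none or still open, it means among the compounds named here.

Measured so far:
compound 1 `CCOC(=O)c1cn(C(c2ccccc2)c2cc3cc(Br)ccc3nc2OC)nn1` gives -3.67% in an ADME assay on HeLa cells (Homo sapiens) for cytotoxicity, read by sulforhodamine B assay, with a stated time of 48 h, tested at 10 uM; a higher number here means more inhibition at the concentration tested (going by the name of the read-out), a lower number less inhibition
compound 2 `COc1nc2ccc(Br)cc2cc1C(c1ccccc1)n1cc(CO)nn1` gives 0.25% in this assay

Compound 2 holds the highest of the two numbers measured, yet its nearest neighbour, compound 1, sits only a number 3.9 percentage points higher from compound 1 to compound 2 (within the scatter) away, so the two show no real order. Within the data shown here, that single step, which swapped ethoxycarbonyl for hydroxymethyl on the same aromatic carbon, is the only measured step, and it bears on compound 3 only loosely.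

Compound 3 `COc1nc2ccc(Br)cc2cc1C(c1ccccc1)n1cc(C2CC2)nn1` has not yet been measured. The change that produces it from compound 2 is cyclopropyl in place of hydroxymethyl on an aromatic carbon. Among the measured compounds shown here, no measured step exchanges a hydroxymethyl group for a cyclopropyl ring, so nothing beyond the scatter is expected in this assay, because the only comparable step, a number 3.9 percentage points higher from compound 1 to compound 2 (within the scatter), stayed inside it.

Compound 3 is therefore estimated at 2%, with a range of -10% to 15%, an expected step of a number 1.8 percentage points higher from compound 2 to compound 3 (within the scatter).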

Compound 3, a percentage reported as inhibition, at one concentration (the size of the read-out at that concentration, not a potency): -5.84%
Beside the measured number, compound 3's estimate is 7.8 percentage points above it; the measured number falls inside the stated range.
By their numbers in this assay, from the lowest: compounds 3, 1 and 2 (each within the scatter of the next).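

Among these compounds, exchanging hydroxymethyl for cyclopropyl on the aromatic carbon of the five-membered ring gives a number 6.1 percentage points lower from compound 2 to compound 3 (within the scatter) in this assay, and this is the first measured change that removes the hydrogen-bond donor and acceptor at this carbon. Exchanging ethoxycarbonyl for cyclopropyl at the same carbon gives a number 2.2 percentage points lower from compound 1 to compound 3 (within the scatter) and also introduces a three-membered ring of carbon only. Ethoxycarbonyl, hydroxymethyl and cyclopropyl therefore cannot be put in any order here, and neither the donor and acceptor count nor this ring brings a change that stands clear of the scatter. Nothing available accounts for this result.

Still open, on these data alone, is whether an amine, a carboxylic acid or a longer alkyl chain at this carbon would stand clear of the scatter. The compounds shown also leave open whether changing the bromine or the methoxy group on the shared core would do so.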